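The compounds below may be only part of what the source reports. "The series", "measured", "known", "first", "only" and "open" are said of these compounds alone.

Measured compounds:
- compound 1 `O=S(=O)(CC1=NCCS1)C1C(c2ccccc2)=NOC1c1ccccc1`: in a functional assay, read by Griess assay, with a stated time of 150 min, tested at 100 ug/mL (on this read-out higher numbers stand for a stronger effect at the one concentration tested and lower numbers for a weaker effect), compound 1 is reported as "not active" (no number reported)
- compound 2 `COc1ccc(C2=NOC(c3ccc(C)cc3)C2S(=O)(=O)CC2=NCCO2)cc1`: compound 2 gives 71.3%
- compound 3 `COc1ccc(C2=NOC(c3ccc(C)cc3)C2S(=O)(=O)CC2=NCCS2)cc1`: compound 3 gives 59.6%

Compound 2 and compound 3 share one core and differ only in the ring attached on the saturated chain carbon bound to a sulfonyl sulfur, (a group of 5 heavy atoms (3 carbon, 1 nitrogen, 1 oxygen; one five-membered non-aromatic ring with 2 hetero atoms) in place of a group of 5 heavy atoms (3 carbon, 1 nitrogen, 1 sulfur; one five-membered non-aromatic ring with 2 hetero atoms), on a saturated chain carbon bound to a sulfonyl sulfur). This exchange gives a number 11.7 percentage points higher from compound 3 to compound 2 (beyond the scatter). Compound 1 carries the other core; how the two cores differ is not broken down here, and compound 1 has no single number, only the report that it is not active.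

Compound 4 `O=S(=O)(CC1=NCCO1)C1C(c2ccccc2)=NOC1c1ccccc1` is not yet measured. Among the compounds with values here, it arises from compound 1 by the same change, (a group of 5 heavy atoms (3 carbon, 1 nitrogen, 1 oxygen; one five-membered non-aromatic ring with 2 hetero atoms) in place of a group of 5 heavy atoms (3 carbon, 1 nitrogen, 1 sulfur; one five-membered non-aromatic ring with 2 hetero atoms), on a saturated chain carbon bound to a sulfonyl sulfur), at the same place, so the step from compound 1 to compound 4 is expected to be of a size like the one from compound 3 to compound 2, a modest gain. Since compound 1 starts from no measurable activity, compound 4 is expected to stay weak, with the estimate 15% and a range from 0% to 40%; a report of no activity again is quite possible.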

Compound 4, a percentage reported as activity, at one concentration (the size of the read-out at that concentration, not a potency): 62.8%
Compound 4: middle estimate off by 47.8 percentage points, on the low side; measured number outside the range, above it.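

Within the data shown here, compound 1 has no number, only the report that it is not active, and no step to compound 4 can be read from it. The compounds shown leave open how large this ring exchange is on the core of compound 1, and how the two cores compare. No measured evidence bears on this result.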